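This account rests on a few compounds, and the source may have more. Where it says the series, first, only, none or still open, it means among the compounds named here.

In a functional assay on the whole organism for inhibition, with Rattus norvegicus as the target (on this read-out lower numbers stand for an effect already at smaller amounts and higher numbers for an effect only at larger amounts of compound), compound 1 (`Oc1nnc(-c2nc3cc(Cl)ccc3o2)o1`) gives 16 mg/kg, compound 2 (`COC(=O)c1cc(OC)c2oc(-c3nnc(O)o3)nc2c1`) gives 9 mg/kg and compound 3 (`Cn1c(-c2nnc(O)o2)nc2ccccc21`) gives 1 mg/kg. That last number is the lowest of the three, and its distance to each of the others lies beyond the scatter. Compound 4 (`Cc1ccc2c(c1)nc(-c1nnc(O)o1)n2C`) differs from compound 3 in one place: methyl in place of hydrogen on an aromatic carbon, with methyl in place of hydrogen on an aromatic carbon. Within the data shown here, no measured pair shows what this change does, so the expectation remains loose. The expected change is a 2.0-fold higher number from compound 3 to compound 4 (0.30 log units; within the scatter), a small move towards a higher number and not clearly beyond the scatter. For compound 4 the estimated value in this assay is 2 mg/kg, with an expected range of 0.6 mg/kg to 6 mg/kg.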

Compound 4, dose for half-maximal effect: 5 mg/kg
Compound 4: the middle estimate sits 2.5-fold (0.40 log units) below what was measured; the measured number falls inside the stated range.
By their numbers in this assay, from the lowest: compound 3; then compounds 4, 2 and 1 (each within the scatter of the next, the first and the last beyond it).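

In this assay, methyl in place of hydrogen on an aromatic carbon, meta to a fused ring and para to a fused ring, gives a 5.0-fold higher number from compound 3 to compound 4 (0.70 log units; beyond the scatter). Among these compounds, this is the first step that can be read at this position, and it shows that even this small group moves the number away from the lowest value. Nothing at hand gives a reason for the rise. On these data alone, whether an ethyl group, a fluorine or an amine on the same carbon would shift the number as methyl does stays open. So does whether the other aromatic carbons of that ring respond in the same way.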